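A methoxy added to the aryl ring of compound 2

This account rests on a few compounds, and the source may have more. Where it says the series, first, only, none or still open, it means among the compounds named here.

Three compounds share one core and differ at its edges. Compound 1 `O=C(N/N=C/c1ccco1)c1cc(-c2ccccc2)nn1Cc1ccccc1` gives 8780 nM in a physicochemical assay on A549 cells for solubility, read by microscopy, with a stated time of 24 h; on this read-out lower numbers stand for stronger inhibition and higher numbers for weaker inhibition. Compound 2 `O=C(N/N=C/c1ccccc1O)c1cc(-c2ccccc2)nn1Cc1ccccc1` gives 650 nM in this assay, and compound 3 `CC(C)(C)c1ccc(Cn2nc(-c3ccccc3)cc2C(=O)N/N=C/c2ccccc2O)cc1` gives 560 nM. Compound 2 stands second highest of the three numbers, within the scatter of compound 3 and far from compound 1, as the step of a 14-fold lower number from compound 1 to compound 2 (1.13 log units; beyond the scatter) shows. The unmeasured compound 4 `COc1ccc(-c2cc(C(=O)N/N=C/c3ccccc3O)n(Cc3ccccc3)n2)cc1` differs from compound 2 by methoxy in place of hydrogen on an aromatic carbon. Within the data shown here, no measured step touches this ring directly. The step of a 1.2-fold lower number from compound 2 to compound 3 (0.06 log units; within the scatter) is the nearest comparison, a small group placed on another aromatic ring of the same molecule, and it stayed within the scatter; the large step of a 14-fold lower number from compound 1 to compound 2 (1.13 log units; beyond the scatter) concerns a different end of the molecule. Compound 4 is therefore expected to show a step of a 1.1-fold lower number from compound 2 to compound 4 (0.03 log units; within the scatter) that remains within the scatter. Compound 4 is estimated at 600 nM in this assay, with a range from 250 nM to 1500 nM.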

Compound 4, half-maximal inhibitory concentration: 840 nM
The estimate for compound 4 lay 1.4-fold (0.15 log units) below the measured number; the range from low to high includes it.
By their numbers in this assay, from the lowest: compounds 3, 2 and 4 (each within the scatter of the next); then compound 1.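

In this assay, among these compounds, the change from phenyl to 4-methoxyphenyl gives the only measured step at this ring of the shared core, a 1.3-fold higher number from compound 2 to compound 4 (0.11 log units; within the scatter), and that step stays within the scatter. The earlier steps shown here concerned the furan-2-yl end and the tert-butyl on another aromatic ring, so this result adds that methoxy at this place, para to a large group, leaves the number indistinguishable from that of compound 2. Nothing available explains this result.

The compounds shown leave open whether an amine, a carboxylic acid or a longer chain such as butoxy at this same place would also stay within the scatter. They also leave open how methoxy would read elsewhere on this ring.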